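The source may report more compounds than this note shows. Statements on the series, on what has been measured and on what is new or still open speak of the compounds shown alone.

Compound 1 `CC(=O)c1nc([C@@H](O)[C@H](O)[C@H](O)CO)cn1C` gives 5.7 mL/min/kg
Compound 2 `OC[C@@H](O)[C@@H](O)[C@H](O)c1c[nH]c(-c2cscn2)n1` gives 12.7 mL/min/kg

In an in vivo ADME assay on the whole organism (strain 129/SvEvBrd x C57BL/6) for pharmacokinetics, with Mus musculus as the target, at a dose of 1 mg/kg by the intravenous route (on this read-out lower numbers stand for slow clearance and higher numbers for fast clearance), compound 2 reads 12.7 mL/min/kg and stands highest of the two measured compounds, while compound 1 reads 5.7 mL/min/kg and the gap between them lies beyond the scatter. Compound 3 `OC[C@@H](O)[C@@H](O)[C@H](O)c1c[nH]c(-c2ncon2)n1` departs from compound 2 at one place, with 1,2,4-oxadiazol-3-yl in place of 1,3-thiazol-4-yl on an aromatic carbon and the rest of the structure unchanged. Within the data shown here, no pair of measured compounds shows what such an exchange does in this assay so the data offer no direct guide. The expectation therefore stays close to compound 2 at 12.7 mL/min/kg with no step beyond the scatter. The expected move is a 1.3-fold lower number from compound 2 to compound 3 (0.10 log units; within the scatter) and it is a small one. In this assay compound 3 is estimated at 10 mL/min/kg and is expected to fall in the range from 4.5 mL/min/kg to 22 mL/min/kg in most measurements.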

Compound 3, clearance: 11.3 mL/min/kg
Compound 3: middle estimate off by 1.1-fold (0.05 log units), on the low side, and the stated range covers the measured number.
By their numbers in this assay, from the lowest: compounds 1, 3 and 2 (each within the scatter of the next, the first and the last beyond it).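

Among these compounds, replacing 1,3-thiazol-4-yl with 1,2,4-oxadiazol-3-yl, on an aromatic carbon between two ring nitrogen atoms, gives the first direct reading of a change at this position: in this assay the step is a 1.1-fold lower number from compound 2 to compound 3 (0.05 log units; within the scatter) and the two compounds cannot be told apart. At this position, then, a five-membered aromatic ring with 3 hetero atoms and one with 2 hetero atoms give matching clearance, at least for this one pair. Nothing measured here explains this result.

Compound 1 differs from these compounds in more than one place, so its reading says nothing about this position alone. As far as these compounds go, it remains open whether clearance would hold with a six-membered pyridine ring, a carboxylic acid or an amine on this carbon.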